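Swapping the amide nitrogen substituent: from benzothiazole to carbamoylphenyl

The compounds below may be only part of what the source reports. "The series", "measured", "known", "first", "only" and "open" are said of these compounds alone.

Measured compounds:
- compound 1, `C=C(CC)C(=O)c1ccc(OCC(=O)Nc2ccc(C(=O)O)cn2)c(Cl)c1Cl`, with 14900 nM in a functional assay on CLL cells (Homo sapiens) for cytotoxicity, read by MTT assay, with a stated time of 48 h; a higher number here means that more compound is needed for the effect, a lower number that less compound is needed
- compound 2, `C=C(CC)C(=O)c1ccc(OCC(=O)Nc2nc3ccccc3s2)c(Cl)c1Cl`, with 1500 nM in this assay
- compound 3, `C=C(CC)C(=O)c1ccc(OCC(=O)Nc2ccc(/C=C/C(=O)OCC)cc2)c(Cl)c1Cl`, with 1700 nM in this assay

Compound 2 gives the lowest of the three numbers in this assay. Compound 3 sits closest to it, with a difference that stays within the scatter, so the two cannot be ranked against each other. Within the data shown here, compound 1 is the furthest away; the only step between compounds that differ in one place, a 9.9-fold lower number from compound 1 to compound 2 (1.00 log units; beyond the scatter), shows that the choice of group on the amide-type nitrogen can move the number well beyond the scatter.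

The new compound, compound 4, `C=C(CC)C(=O)c1ccc(OCC(=O)Nc2ccc(C(N)=O)cc2)c(Cl)c1Cl`, alters compound 2 at the same position: 4-carbamoylphenyl in place of 1,3-benzothiazol-2-yl on an amide-type nitrogen. The step from compound 1 to compound 2 also replaced the group on that nitrogen, so it bears on this change. The values of compounds 2 and 3 show that a six-membered carbon-only ring bearing a substituent can give a number close to that of compound 2. Compound 1, however, which carries a carboxylic acid on its ring, shows that a carboxylic acid on that ring can go with a number far higher. The carbamoyl group of compound 4 resembles neither case exactly, so a moderate rise in this assay is expected, a 2.5-fold higher number from compound 2 to compound 4 (0.40 log units; beyond the scatter). For compound 4 the estimated value is 3800 nM, with a range from 1500 nM to 12000 nM.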

Compound 4, half-maximal effective concentration: 3700 nM
Compound 4: middle estimate off by 1.0-fold (0.01 log units), on the high side; low and high end bracket the measured number.
By their numbers in this assay, from the lowest: compounds 2 and 3 (each within the scatter of the next); then compound 4; then compound 1.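

In this assay, the step of a 2.5-fold higher number from compound 2 to compound 4 (0.39 log units; beyond the scatter) and the step of a 2.2-fold higher number from compound 3 to compound 4 (0.34 log units; beyond the scatter) both lie beyond the scatter, so a six-membered carbon-only ring on the amide-type nitrogen does not by itself keep the number level with that of compound 2, and the group on that ring can shift it, here with carbamoyl in place of 2-(ethoxycarbonyl)ethenyl. Among these compounds, the step of a 4.0-fold lower number from compound 1 to compound 4 (0.60 log units; beyond the scatter) places compound 4 clearly apart from compound 1 as well, giving a middle level that the earlier compounds did not show, although 4-carbamoylphenyl differs from 5-carboxypyridin-2-yl in both its ring and its substituent, so this step cannot be assigned to either change alone. Nothing available explains why these numbers differ.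

As far as these compounds go, it remains open whether the high number of compound 1 goes with the carboxylic acid or with the ring nitrogen, a question that a 4-carboxyphenyl group on the same amide-type nitrogen would address. How an amine or a longer chain in place of the carbamoyl would move the number in this assay is also unknown from these compounds.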